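Chain extension from compound 2 to compound 3

The source may hold more compounds than are shown below. What is called first, only, known or untested is meant among the compounds shown, and "the series" means these compounds.

- compound 1 `Nc1ncnc2c1c(-c1cnc3[nH]ccc3c1)nn2CCCCCCCCC(=O)NO` gives 12300 nM in a functional assay on A549 cells (Homo sapiens) for inhibition, read by MTT assay, with a stated time of 72 h; a lower number here means a stronger inhibitor, a higher number a weaker inhibitor
- compound 2 `Nc1nc2cc(-c3nn(CCCCCC(=O)NO)c4ncnc(N)c34)ccc2o1` gives > 100000 nM in this assay

Compound 2 stands on a limit of the assay (> 100000 nM) and not on a number. Compound 3 `Nc1nc2cc(-c3nn(CCCCCCCCC(=O)NO)c4ncnc(N)c34)ccc2o1` is still to be measured in this assay. Relative to compound 2, it has 3-(hydroxycarbamoyl)propyl in place of hydroxycarbamoyl on a saturated chain carbon, five bonds along the chain from an aromatic nitrogen. Going by the values given here, no measured step isolates this change, so any expectation rests on thin ground. Among the compounds with values here, compound 1 gives 12300 nM and is the only compound here with a number, so a move toward a lower number, meaning a stronger inhibitor, is expected, of a size beyond the scatter. The estimated change is an at least 6.6-fold lower number from compound 2 to compound 3 (0.82 log units; beyond the scatter) in that direction. Compound 3 is expected at 15000 nM (estimated range 4000 nM to 60000 nM).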

Compound 3, half-maximal inhibitory concentration: 13200 nM
Estimate against measurement, compound 3: 1.1-fold (0.06 log units) above, and the stated range covers the measured number.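

In this assay, 3-(hydroxycarbamoyl)propyl in place of hydroxycarbamoyl at this chain position gives an at least 7.5-fold lower number from compound 2 to compound 3 (0.87 log units; beyond the scatter), so the longer chain brings this core onto a measurable number. Going by these compounds, compound 2 stands on a limit, so the true size of this step stays open: the limit of > 100000 nM in this assay, at which 1 of the 3 values shown sits. With the longer chain held fixed, the exchange of the group on the aromatic carbon gives a 1.1-fold higher number from compound 1 to compound 3 (0.03 log units; within the scatter), so the two values cannot be told apart.

The compounds shown leave open how the number follows chain length, whether it turns at a chain of intermediate length or keeps moving with a still longer chain. They also leave open whether the terminal hydroxycarbamoyl group matters at this length, which a carboxylic acid or a primary amide at the chain end would test.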